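Bromo in place of methoxy: notes on compound 4

The source may report more compounds than this note shows. Statements on the series, on what has been measured and on what is new or still open speak of the compounds shown alone.

Values in a functional assay on HepG2 cells (Homo sapiens) for inhibition, read by MTT assay, with a stated time of 48 h; on this read-out higher numbers stand for weaker inhibition and lower numbers for stronger inhibition:
- compound 1 `COc1ccc(/C=C2\SC(=O)N(CCNC(=O)Nc3c(C)n(C)n(-c4ccccc4)c3=O)C2=O)cc1`: 8370 nM
- compound 2 `Cc1c(NC(=O)NCCN2C(=O)S/C(=C\c3ccc([N+](=O)[O-])cc3)C2=O)c(=O)n(-c2ccccc2)n1C`: 14000 nM
- compound 3 `COc1ccc(/C=C2\SC(=O)N(CC(=O)Nc3c(C)n(C)n(-c4ccccc4)c3=O)C2=O)cc1`: 68500 nM

Compound 3 at 68500 nM has the highest of the three numbers, beyond the scatter of both others. Compound 4 `Cc1c(NC(=O)CN2C(=O)S/C(=C\c3ccc(Br)cc3)C2=O)c(=O)n(-c2ccccc2)n1C` carries bromo in place of methoxy on an aromatic carbon. Within the data shown here, no measured compound carries bromo. Among the measured compounds shown here, the only measured step at this aromatic carbon is a 1.7-fold higher number from compound 1 to compound 2 (0.22 log units; within the scatter), for nitro in place of methoxy, and it was measured on a different chain from that of compound 3. No step beyond the scatter is therefore expected in this assay. The estimated step is a 1.1-fold lower number from compound 3 to compound 4 (0.06 log units; within the scatter). For compound 4 the expected value is 60000 nM, with an estimated range of 25000 nM to 130000 nM.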

Compound 4, half-maximal inhibitory concentration: 19200 nM
Beside the measured number, compound 4's estimate is 3.1-fold (0.49 log units) above it; measured number below the stated range.
By their numbers in this assay, from the lowest: compounds 1, 2 and 4 (each within the scatter of the next, the first and the last beyond it); then compound 3.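

In this assay the change from 4-methoxyphenyl to 4-bromophenyl gives a 3.6-fold lower number from compound 3 to compound 4 (0.55 log units; beyond the scatter) on the chain of compound 3, so a change at this aromatic carbon can move the number beyond the scatter. The earlier step at the same carbon (a 1.7-fold higher number from compound 1 to compound 2 (0.22 log units; within the scatter)) stayed within the scatter, on a different chain and with nitro as the entering group. No measurement here accounts for the new step.

On these data alone, whether bromo gives a step of similar size on the chain of compound 1 remains open. So does the effect on the number of an amine or a carboxylic acid at this aromatic carbon.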